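Cyclic peptide series: side-chain swap at the isopropyl carbon

A few compounds are considered here, and "the series" means these few. Any claim that something is new, unique, unknown or untested is made for them only; others in the source may bear on it.

Among the compounds with values here, compound 2 `CC(C)[C@@H]1NC(=O)[C@H](CCCNC(=N)N)NC(=O)CNC(=O)C[C@@H](C(=O)O)NC(=O)[C@@H](c2ccccc2)NC1=O` gives 115 nM in an assay on a protein complex for binding affinity to integrin alpha-5/beta-1 (Homo sapiens), read by ELISA (on this read-out higher numbers stand for weaker inhibition and lower numbers for stronger inhibition), the highest of the two numbers measured so far. Compound 1 `N=C(N)NCCC[C@@H]1NC(=O)CNC(=O)C[C@@H](C(=O)O)NC(=O)[C@@H](c2ccccc2)NC(=O)CNC1=O` differs only in bearing hydrogen where compound 2 bears isopropyl; in this assay compound 1 gives 19 nM. The step of a 6.1-fold higher number from compound 1 to compound 2 (0.78 log units; beyond the scatter) is modest but beyond the scatter. Compound 3 `N=C(N)NCCC[C@@H]1NC(=O)CNC(=O)C[C@@H](C(=O)O)NC(=O)[C@@H](c2ccccc2)NC(=O)[C@H](CCCCN)NC1=O` carries 4-aminobutyl in place of isopropyl on a saturated ring carbon. Within the data shown here, no measured step covers the exchange of isopropyl for 4-aminobutyl, so the only step that bears on it is the one from compound 1 to compound 2, which shows that a group at this ring carbon can move the number beyond the scatter. The expectation for compound 3 is a modest move back toward the number of compound 1, a 1.9-fold lower number from compound 2 to compound 3 (0.28 log units; within the scatter), with wide uncertainty. Compound 3 is therefore estimated at 60 nM in this assay, within a range of 15 nM to 250 nM.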

Compound 3, half-maximal inhibitory concentration: 94 nM
Estimate against measurement, compound 3: 1.6-fold (0.19 log units) below, and the stated range covers the measured number.
By their numbers in this assay, from the lowest: compound 1; then compounds 3 and 2 (each within the scatter of the next).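

In this assay, exchanging isopropyl for 4-aminobutyl on this saturated ring carbon gives a 1.2-fold lower number from compound 2 to compound 3 (0.09 log units; within the scatter), so this read-out does not separate the two groups, although 4-aminobutyl brings a nitrogen and a longer chain. Against hydrogen at the same carbon, 4-aminobutyl gives a 4.9-fold higher number from compound 1 to compound 3 (0.69 log units; beyond the scatter), so in compounds 2 and 3 two different side chains both stand beyond the scatter from compound 1, and neither compound goes against this within the three shown. Nothing at hand bears on the reason for this.

A plain butyl chain would separate the effect of chain length from that of the terminal amine in compound 3. As far as these compounds go, a methyl group or a chain ending in a carboxylic acid at this carbon remains open, as does whether any group here comes back to the number of compound 1.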